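Ether chain length in the series: expectation for compound 4

The source may report more compounds than this note shows. Statements on the series, on what has been measured and on what is new or still open speak of the compounds shown alone.

Measured compounds:
compound 1 `CCCC1(CC=C(C)C)C(=O)C(C(=O)/C=C/c2ccccc2)=C(O)C(CCC)(CCC)C1=O`: 8.2 uM in a functional assay on KB cells (Homo sapiens) for antiproliferative activity, read by sulforhodamine B assay, with a stated time of 3 days; a higher number here means that more compound is needed for the effect, a lower number that less compound is needed
compound 2 `CCCC1=C(OCC(C)C)C(CCC)(CCC)C(=O)/C(=C(O)\C=C\c2ccccc2)C1=O`: 4.8 uM
compound 3 `CCCC1=C(OCC)C(CCC)(CCC)C(=O)/C(=C(O)\C=C\c2ccccc2)C1=O`: 6.4 uM

Compound 3 sits within the scatter of both compound 1 and compound 2; the three numbers cannot be told apart. Compound 4 `CCCCOC1=C(CCC)C(=O)/C(=C(O)/C=C/c2ccccc2)C(=O)C1(CCC)CCC` differs from compound 3 in one place: ethyl in place of hydrogen on a saturated chain carbon, two bonds along the chain from an oxygen on an unsaturated carbon. For the measured compounds named here, the only measured step touching the same ether chain is a 1.3-fold higher number from compound 2 to compound 3 (0.12 log units; within the scatter), which changed nothing beyond the scatter. Lengthening the chain in compound 4 is therefore expected to give a step of about a 1.1-fold lower number from compound 3 to compound 4 (0.03 log units; within the scatter), that is, no change beyond the scatter in this assay. Compound 4 is estimated at 6 uM, with a range from 3 uM to 12 uM.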

Compound 4, concentration for half-maximal effect: 8 uM
Compound 4: the middle estimate sits 1.3-fold (0.12 log units) below what was measured; low and high end bracket the measured number.
By their numbers in this assay, from the lowest: compounds 2, 3, 4 and 1 (each within the scatter of the next).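

Ethoxy to butoxy gives a 1.3-fold higher number from compound 3 to compound 4 (0.10 log units; within the scatter) in this assay and propyl in place of isopropyl gives a 1.7-fold higher number from compound 2 to compound 4 (0.22 log units; within the scatter) on the same ether chain. The ether position thus holds ethyl, isopropyl-bearing and butyl-length chains without a change beyond the scatter, and the longer straight chain adds no step beyond it. No supporting data explain this tolerance.

Still open, as far as these compounds go, is whether a chain longer than butoxy, or an ether ending in an amine or a carboxylic acid, would move the number beyond the scatter.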